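The source may report more compounds than this note shows. Statements on the series, on what has been measured and on what is new or still open speak of the compounds shown alone.

Of the compounds shown here, three sharing one core have been tested in a functional assay on A549 cells (Homo sapiens) for cytotoxicity, read by MTT assay, with a stated time of 48 h; on this read-out lower numbers stand for stronger inhibition and higher numbers for weaker inhibition. Compound 3 (`CCN(CC)CCCOc1cc(O)c2c(=O)cc(-c3ccccc3)oc2c1OC`) gives 1830 nM, the lowest number of the set, while compound 1 (`COc1c(OCCCCNCc2ccccc2)cc(O)c2c(=O)cc(-c3ccccc3)oc12`) gives 4590 nM and compound 2 (`COc1c(OCCCN2CCN(C)CC2)cc(O)c2c(=O)cc(-c3ccccc3)oc12`) gives 9900 nM. In compound 4 (`COc1c(OCCCCN2CCN(C)CC2)cc(O)c2c(=O)cc(-c3ccccc3)oc12`), not yet measured, (4-methylpiperazin-1-yl)methyl stands in place of diethylamino on a saturated chain carbon, three bonds along the chain from an oxygen on an aromatic ring: (4-methylpiperazin-1-yl)methyl in place of diethylamino on a saturated chain carbon, three bonds along the chain from an oxygen on an aromatic ring.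

The closest guide is a 5.4-fold lower number from compound 2 to compound 3 (0.73 log units; beyond the scatter), where diethylamino replaced 4-methylpiperazin-1-yl, so the present change runs broadly the opposite way. The steps of a 2.2-fold higher number from compound 1 to compound 2 (0.33 log units; beyond the scatter) and a 2.5-fold lower number from compound 1 to compound 3 (0.40 log units; beyond the scatter) are smaller and involve (benzylamino)methyl, so they bear on it less directly, though they show that the side group matters in this assay. A rise of modest size, beyond the scatter, is therefore expected. The expected step is a 3.8-fold higher number from compound 3 to compound 4 (0.58 log units; beyond the scatter). For compound 4 the estimated value is 7000 nM, with an expected range from 3000 nM to 16000 nM.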

Compound 4, half-maximal inhibitory concentration: 1500 nM
Beside the measured number, compound 4's estimate is 4.7-fold (0.67 log units) above it; measured number outside the range, below it.
By their numbers in this assay, from the lowest: compounds 4 and 3 (each within the scatter of the next); then compound 1; then compound 2.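

In this assay, the 4-methylpiperazin-1-yl group does not by itself go with a high number: putting (4-methylpiperazin-1-yl)methyl in its place on the saturated chain carbon gives a 6.6-fold lower number from compound 2 to compound 4 (0.82 log units; beyond the scatter) for that one change. Set against diethylamino, the same group gives a 1.2-fold lower number from compound 3 to compound 4 (0.09 log units; within the scatter) at this position, so the low number of compound 3 is not particular to diethylamino. The end group still counts, since 4-methylpiperazin-1-yl in place of benzylamino, four bonds along the chain from an oxygen on an aromatic ring, gives a 3.1-fold lower number from compound 1 to compound 4 (0.49 log units; beyond the scatter) in this series.

Going by these compounds, how a morpholine or a still longer chain would read at this position remains open. Nothing measured here explains why these numbers differ.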